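This account rests on a few compounds, and the source may have more. Where it says the series, first, only, none or still open, it means among the compounds named here.

Compound 1 `Cc1nc2ccc(Br)cc2c(=O)n1NCc1nnc(N2C(=O)CSC2c2ccc(N(C)C)cc2)s1` was tested in a functional assay on the whole organism (strain albino) with Rattus norvegicus as the target, in the maximal electroshock model, with a stated time of 1 h, at a dose of 30 mg/kg by the intraperitoneal route (a lower number here means less inhibition, a higher number more inhibition at the dose given (going by the name of the read-out)), where compound 1 gave 60%. Going by the values given here, its only measured neighbour, compound 2 `Cc1nc2ccccc2c(=O)n1NCc1nnc(N2C(=O)CSC2c2ccc(N(C)C)cc2)s1`, gave 60% in this assay, and the step of no change at the digits printed from compound 1 to compound 2 (within the scatter) shows that removing the bromo left the read-out where it was; compound 1 therefore stands level with compound 2 on the numbers in hand. Compound 3 `COc1ccc(C2SCC(=O)N2c2nnc(CNn3c(C)nc4ccc(Br)cc4c3=O)s2)cc1` carries a different change on the shared core: methoxy in place of dimethylamino on an aromatic carbon. Among the compounds with values here, no measured step touches this position; the one step available concerns the bromo and is of no direct bearing on an exchange of dimethylamino for methoxy. With nothing in the data pointing either way, the step of no change at the digits printed from compound 1 to compound 3 (within the scatter) is expected to be no change beyond the scatter. Compound 3 is thus estimated to give 60% in this assay, with a range from 40% to 80%.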

Compound 3, a percentage reported as inhibition, in the whole organism at one dose (the size of the read-out at that dose, not a potency): 60%
Beside the measured number, compound 3's estimate shows no gap at the digits printed; measured number inside the range.
By their numbers in this assay, from the lowest: compounds 1, 2 and 3 (each within the scatter of the next).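

In this assay, the step at this position reads no change at the digits printed from compound 1 to compound 3 (within the scatter), which gives the aromatic carbon para to a large group a measured result of its own, something the earlier bromo step could not supply. Since the two compounds differ in this one place, going from 4-(dimethylamino)phenyl to 4-methoxyphenyl is shown to leave the read-out at this single dose in place, so dimethylamino is not needed here to keep it. Nothing measured explains why the two groups read alike.

Still open, from the compounds shown here alone, is whether a hydroxyl group, a carboxylic acid or a longer alkoxy chain at this place would hold the read-out too. Also open, going by these compounds, is whether methoxy would do the same on the core without the bromo, and whether compound 1 and compound 3 would stay level at other doses.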